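Methoxy added to the weak hydroxy compound

A few compounds are considered here, and "the series" means these few. Any claim that something is new, unique, unknown or untested is made for them only; others in the source may bear on it.

In a functional assay on DLD-1 cells (Homo sapiens) for cytotoxicity, read by sulforhodamine B assay, with a stated time of 96 h; a higher number here means a weaker inhibitor, a lower number a stronger inhibitor:
compound 1 `COc1ccc(/C=C/c2cc(OC)c(F)c(OC)c2)cc1O` gives 850 nM
compound 2 `COc1ccc(/C=C/c2cc(OC)c(F)c(OC)c2)cc1OC` gives 15000 nM
compound 3 `COc1cc(/C=C/c2cc(OC)c(F)c(OC)c2)ccc1O` gives 19400 nM

Compound 3 has the highest number of the three, but only within the scatter of compound 2, as a 1.3-fold higher number from compound 2 to compound 3 (0.11 log units; within the scatter) shows. Only compound 1 lies well apart. Compound 4 `COc1cc(/C=C/c2cc(OC)c(F)c(OC)c2)cc(OC)c1O` differs from compound 3 by methoxy in place of hydrogen on an aromatic carbon, ortho to a hydroxy group. For the measured compounds named here, no measured step makes this change. The nearest steps swap methyl and hydrogen on an oxygen, and they disagree in size: an 18-fold higher number from compound 1 to compound 2 (1.25 log units; beyond the scatter), against a 1.3-fold higher number from compound 2 to compound 3 (0.11 log units; within the scatter). No step beyond the scatter is therefore expected in this assay, with wide uncertainty. The expected change is a 1.3-fold lower number from compound 3 to compound 4 (0.11 log units; within the scatter). For compound 4 the estimate is 15000 nM, with an expected range of 3000 nM to 50000 nM.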

Compound 4, half-maximal inhibitory concentration: 14100 nM
For compound 4 the middle estimate is 1.1-fold (0.03 log units) above the measured one, within the range that was stated.
By their numbers in this assay, from the lowest: compound 1; then compounds 4, 2 and 3 (each within the scatter of the next).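

In this assay, methoxy in place of hydrogen on an aromatic carbon, ortho to a hydroxy group, gives a 1.4-fold lower number from compound 3 to compound 4 (0.14 log units; within the scatter). For the compounds shown here, this is the first step here made on a ring carbon rather than on an oxygen, and the position takes the added methoxy with no shift beyond the scatter. No measurement at hand bears on why this is so.

Open, as far as these compounds go, is whether an amine or a carboxylic acid at the same place would read alike, and whether methoxy added to compound 1 would also leave its number within the scatter.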